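Trifluoromethyl replacing hydrogen on a chalcone-bearing core

A few compounds are considered here, and "the series" means these few. Any claim that something is new, unique, unknown or untested is made for them only; others in the source may bear on it.

Three compounds share one core and differ only in one substituent on the six-membered aromatic ring of carbon only. In a functional assay on HCT-116 cells (Homo sapiens) for antiproliferative activity, read by MTT assay, with a stated time of 24 h (on this read-out lower numbers stand for stronger inhibition and higher numbers for weaker inhibition), compound 1 `COc1ccc(C(=O)/C=C/c2cccc(F)c2)c2c1C=CC(C)(C)O2` gives > 10000 nM, which is a limit of the assay and not a number. Compound 2 `COc1ccc(C(=O)/C=C/c2cccc([N+](=O)[O-])c2)c2c1C=CC(C)(C)O2`, which carries a nitro at that position, gives 8050 nM in this assay. Compound 3 `COc1ccc(C(=O)/C=C/c2ccccc2)c2c1C=CC(C)(C)O2` gives > 10000 nM in this assay, again a limit rather than a number. Compound 3 thus stands at the limit, together with compound 1 (the limit of > 10000 nM in this assay, at which 2 of the 3 values shown sit), while compound 2 alone returns a number.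

Compound 4 `COc1ccc(C(=O)/C=C/c2cccc(C(F)(F)F)c2)c2c1C=CC(C)(C)O2` differs from compound 3 by trifluoromethyl in place of hydrogen on an aromatic carbon. Going by the values given here, two measured steps bear on substitution at this position: an at least 1.2-fold higher number from compound 2 to compound 3 (0.09 log units; that floor lies within the scatter), and a step that the two limits leave unreadable from compound 1 to compound 3. Neither step shows a change that rises beyond the scatter, and the nitro is the only substituent that brought the read-out inside the measurable range at all. The step that the limit leaves unreadable from compound 3 to compound 4 is therefore expected to be small, with compound 4 most likely remaining near the limit. Compound 4 is estimated at 12000 nM, within a range from 5000 nM to 40000 nM, in this assay.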

Compound 4, half-maximal inhibitory concentration: 9710 nM
Compound 4: middle estimate off by 1.2-fold (0.09 log units), on the high side, and the stated range covers the measured number.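

In this assay, trifluoromethyl joins nitro as a group at this position that returns a number rather than a limit, and a 1.2-fold higher number from compound 2 to compound 4 (0.08 log units; within the scatter) places the two readings within the scatter of each other. Against hydrogen the change reads as an at least 1.0-fold lower number from compound 3 to compound 4 (0.01 log units; that floor lies within the scatter), and against fluoro as an at least 1.0-fold lower number from compound 1 to compound 4 (0.01 log units; that floor lies within the scatter); both floors stay within the scatter, so no gain beyond the scatter can be claimed for trifluoromethyl over either group. Compound 1 and compound 3 remain at a limit of the assay, which is not a number: the limit of > 10000 nM in this assay, at which 2 of the 4 values shown sit.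

On these data alone, how far compound 1 and compound 3 actually lie past that limit stays open, and with it the true size of these two steps. Whether any group at this position can move the read-out beyond the scatter is also unanswered, and an amine or a carboxylic acid on this aromatic carbon would be the next groups to bear on that question.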